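This account rests on a few compounds, and the source may have more. Where it says the series, first, only, none or still open, it means among the compounds named here.

Compound 1, with the structure `COc1cc(CNCc2ccncc2)ccc1OCc1cccc(F)c1`, is one of three compounds tested in a functional assay on HeLa cells (Homo sapiens) for inhibition, with a stated time of 72 h (on this read-out lower numbers stand for an effect already at smaller amounts and higher numbers for an effect only at larger amounts of compound), where compound 1 gives 4800 nM. Among the measured compounds shown here, compound 2, `CCOc1cc(CNCc2ccncc2)ccc1OCc1ccc(Cl)cc1`, gives 2500 nM in this assay, a number that lies within the usual scatter of the one for compound 1, so the two cannot be told apart. Compound 3, `COc1cc(CNCc2ccccn2)ccc1OCc1cccc(Cl)c1`, gives 18000 nM, a number beyond the scatter and higher than that of compound 1. Compound 1 therefore sits with the second highest of the three numbers. Compound 4, `COc1cc(CNCc2ccncc2)ccc1OCc1ccccc1F`, is built from the same atoms joined differently: 2-fluorophenyl in place of 3-fluorophenyl on a saturated chain carbon bound to an oxygen on an aromatic ring. For the measured compounds named here, no measured pair shows what this change does, so the step of no change at the digits printed from compound 1 to compound 4 (within the scatter) is expected to stay within the scatter, in neither direction. Compound 4 is estimated at 4800 nM, between 1800 nM and 13000 nM.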

Compound 4, half-maximal effective concentration: 5100 nM
Beside the measured number, compound 4's estimate is 1.1-fold (0.03 log units) below it; the measured number falls inside the stated range.
By their numbers in this assay, from the lowest: compounds 2, 1 and 4 (each within the scatter of the next, the first and the last beyond it); then compound 3.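

In this assay the change to 2-fluorophenyl in place of 3-fluorophenyl gives a 1.1-fold higher number from compound 1 to compound 4 (0.03 log units; within the scatter) and so cannot be told from repeat-measurement noise. Among the compounds shown here, this is the first direct reading at this position, since no earlier pair differed here alone, and for these two fluorophenyl groups the place of the fluorine makes no measurable difference. Nothing available explains this result. Still open, from the compounds shown here alone, is whether this tolerance extends beyond fluorine, for instance to a trifluoromethyl, a nitrile or a carboxylic acid on that ring. An unsubstituted phenyl would show whether the fluorine matters at all.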